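Shortening the acid chain on the amine side group

The compounds below may be only part of what the source reports. "The series", "measured", "known", "first", "only" and "open" are said of these compounds alone.

Compound 1 `Cc1cn([C@@H]2O[C@H](CO[Si](C)(C)C(C)(C)C)[C@@]3(OS(=O)(=O)C=C3NCCC(=O)O)[C@H]2O[Si](C)(C)C(C)(C)C)c(=O)n(C)c1=O` holds the highest of the two numbers recorded in a functional assay on MT4 cells (Homo sapiens) (on this read-out lower numbers stand for higher toxicity in this test and higher numbers for lower toxicity in this test), where compound 1 gives 11500 nM. For the measured compounds named here, its single measured neighbour, compound 2 `Cc1cn([C@@H]2O[C@H](CO[Si](C)(C)C(C)(C)C)[C@@]3(OS(=O)(=O)C=C3NCC(=O)C(N)=O)[C@H]2O[Si](C)(C)C(C)(C)C)c(=O)n(C)c1=O`, gives 9590 nM, and the step between them is a 1.2-fold lower number from compound 1 to compound 2 (0.08 log units; within the scatter). Compound 3 `Cc1cn([C@@H]2O[C@H](CO[Si](C)(C)C(C)(C)C)[C@@]3(OS(=O)(=O)C=C3NCC(=O)O)[C@H]2O[Si](C)(C)C(C)(C)C)c(=O)n(C)c1=O` has not yet been measured; it differs from compound 1 by carboxy in place of carboxymethyl on a saturated chain carbon bound to an amine nitrogen. Going by the values given here, the one measured step bears on this change only loosely: it alters the same side group at the same place, and the read-out stayed within the scatter, as a 1.2-fold lower number from compound 1 to compound 2 (0.08 log units; within the scatter) shows. The shortening in compound 3 is a change of similar kind at that position, so no step beyond the scatter is expected from it. Compound 3 is therefore estimated at 11000 nM, with a range of 5000 nM to 25000 nM. The step of a 1.0-fold lower number from compound 1 to compound 3 (0.02 log units; within the scatter) is expected to stay within the scatter.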

Compound 3, half-maximal cytotoxic concentration: 30000 nM
Compound 3: middle estimate off by 2.7-fold (0.44 log units), on the low side; the measured number lies above the stated range.
By their numbers in this assay, from the lowest: compounds 2 and 1 (each within the scatter of the next); then compound 3.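

Changing (2-carboxyethyl)amino to (carboxymethyl)amino gives a 2.6-fold higher number from compound 1 to compound 3 (0.42 log units; beyond the scatter) in this assay, so the read-out does respond to a change in this side group, modestly, whereas the earlier step stayed within the scatter. Hydroxy in place of carbamoyl on a carbonyl carbon gives a 3.1-fold higher number from compound 2 to compound 3 (0.50 log units; beyond the scatter), which is also beyond the scatter and sets the carboxymethyl side group apart from the other two side groups shown. Nothing available here accounts for either step.

The compounds shown leave open whether a longer chain carrying the carboxylic acid would follow the same trend as these three compounds. They also leave open whether a methyl ester or a primary amine at the end of the carboxymethyl chain would keep the higher number.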